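The source may hold more compounds than are shown below. What is called first, only, known or untested is meant among the compounds shown, and "the series" means these compounds.

Measured in a functional assay on U2OS cells (Homo sapiens) for antiproliferative activity, read by MTT assay, with a stated time of 72 h; on this read-out lower numbers stand for stronger inhibition and higher numbers for weaker inhibition:
- compound 1 `O=C(CSc1nc2ccccc2[nH]1)Nc1ccc2nc(NC(=O)c3ccc(C(F)(F)F)cc3)sc2c1`: 7110 nM
- compound 2 `O=C(Cn1cc(F)c(=O)n(CC(=O)Nc2ccc(Br)cn2)c1=O)Nc1ccc(Br)cn1`: 5140 nM
- compound 3 `Cn1c(CNC(=O)c2cccs2)nnc1SCC(=O)Nc1ccc(Cl)cc1`: > 100000 nM

Compounds 1 and 2 return numbers, but compound 3 does not. In this assay, compound 3 gives > 100000 nM, which is a limit of the assay and not a number. On these data alone, it stands at the limit of > 100000 nM in this assay, at which 1 of the 3 values shown sits, so its true potency is unknown.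

Compound 4 `Cn1c(CNC(=O)c2cccs2)nnc1SCC(=O)Nc1cccc(Cl)c1` has the same atoms as compound 3, joined differently: 3-chlorophenyl in place of 4-chlorophenyl on an amide-type nitrogen. In other words, it has 3-chlorophenyl in place of 4-chlorophenyl on an amide-type nitrogen. Among the compounds with values here, no measured pair here shows what this kind of change does, and compounds 1 and 2 differ from compound 3 in much more than this one place.

Within the data shown here, the only guide is therefore compound 3 itself, and compound 4 is expected to stay weak in this assay, quite possibly at the same limit. The expected step is small, an at least 1.2-fold lower number from compound 3 to compound 4 (0.09 log units; that floor lies within the scatter), and any gain is not expected to clearly exceed the scatter. The estimate for compound 4 is 80000 nM, with an expected range of 20000 nM to 100000 nM.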

Compound 4, half-maximal inhibitory concentration: > 100000 nM
Compound 4: a limit, no number; the forecaster's own chance of this, stated with the estimate: 60%; middle value at least 1.2-fold (0.09 log units) away from the limit.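

No step can be read between compound 3 and compound 4, because both stop at a limit of the assay and neither gives a number: the limit of > 100000 nM in this assay, at which 2 of the 4 values shown sit.

The compounds shown leave open how strongly each truly inhibits, and whether 3-chlorophenyl in place of 4-chlorophenyl changes potency at all.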